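This account rests on a few compounds, and the source may have more. Where it says the series, first, only, none or still open, it means among the compounds named here.

Compound 1 `CCC(=O)N1CC2CC(C1)N2` and compound 2 `O=C(C1CCC1)N1CC2CC(C1)N2` share one core and differ only in the group on the carbonyl carbon. In an assay on CHO cells for displacement of a labelled ligand from Neuronal acetylcholine receptor; alpha3/alpha6/beta2/beta3 (Homo sapiens), read by scintillation counting (a lower number here means a stronger inhibitor, a higher number a weaker inhibitor), compound 1 gives 190 nM and compound 2 gives 240 nM. Compound 1 has the lower of the two numbers, but the step of a 1.3-fold higher number from compound 1 to compound 2 (0.10 log units; within the scatter) lies within the scatter, so the two compounds cannot be told apart on these data. Compound 3 `O=C(CC1C=CCC1)N1CC2CC(C1)N2` is the next structure, and it differs from compound 1 as follows: cyclopent-2-en-1-yl in place of methyl on a saturated chain carbon bound to a carbonyl carbon. Going by the values given here, the only measured step that bears on this change is a 1.3-fold higher number from compound 1 to compound 2 (0.10 log units; within the scatter), in which a ring in place of a small chain on the carbonyl carbon left the number essentially where it was. The change to compound 3 brings in more carbon again, and the expectation, due to the step of a 1.3-fold higher number from compound 1 to compound 2 (0.10 log units; within the scatter), is that compound 3 will show a step of a 1.6-fold higher number from compound 1 to compound 3 (0.20 log units; within the scatter) that stays small, leaning if anything toward a higher number. For compound 3 the estimate in this assay is therefore 300 nM, with a range from 100 nM to 900 nM.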

Compound 3, inhibition constant: 2500 nM
Compound 3: the middle estimate sits 8.3-fold (0.92 log units) below what was measured; the whole stated range lies below it.
By their numbers in this assay, from the lowest: compounds 1 and 2 (each within the scatter of the next); then compound 3.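

In this assay the change from methyl to cyclopent-2-en-1-yl gives a 13-fold higher number from compound 1 to compound 3 (1.12 log units; beyond the scatter) and so shows that a change on the saturated chain carbon bound to a carbonyl carbon can move the number well beyond the scatter. The earlier pair showed no such sensitivity: a 1.3-fold higher number from compound 1 to compound 2 (0.10 log units; within the scatter) and gave no sign that adding carbon in this part of the molecule could matter much, whereas here a group of 5 heavy atoms, with one five-membered ring and one double bond, replaces a single carbon and the compound binds clearly less well. Nothing measured here explains why the number rises so far.

The compounds shown leave open whether the rise goes with the ring, the double bond or simply the added carbon, as all three enter together in compound 3. A saturated cyclopentyl group or an open pentyl chain at the same place would pull these apart, and an amine on the ring would show whether the place accepts anything other than carbon.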